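Methyl for Acetyl: Weighing the Clearance of Compound 3

The source may report more compounds than this note shows. Statements on the series, on what has been measured and on what is new or still open speak of the compounds shown alone.

Two compounds have so far been run through an in vivo ADME assay on the whole organism for pharmacokinetics, with Rattus norvegicus as the target, at a dose of 0.5 mg/kg by the intravenous route; a lower number here means slower removal, a higher number faster removal of the compound. Compound 2, `CC(=O)Nc1cc(-c2c(Nc3cc[nH]n3)nc3cccnn23)nc(C)n1`, gives 43.3 mL/min/kg in this assay. Compound 1, `CC(=O)Nc1cc(-c2c(Nc3cc[nH]n3)nc3ccccn23)nc(C)n1`, gives 38.3 mL/min/kg in this assay; the two values lie within the scatter of each other, so compound 2 stands level with compound 1 on the numbers known. Compound 3, `CNc1cc(-c2c(Nc3cc[nH]n3)nc3cccnn23)nc(C)n1`, has not yet been measured. It differs from compound 2 in one place: methyl in place of acetyl on a nitrogen on an aromatic ring, or, read one bond further out, acetamido to methylamino. Among the compounds with values here, no pair of measured compounds shows this exchange, so there is no measured step to lean on. The two measured values sit close together, and the expected step of a 1.0-fold lower number from compound 2 to compound 3 (0.01 log units; within the scatter) is taken to stay within the scatter. Compound 3 is therefore expected to give about 42 mL/min/kg in this assay, with a range from 22 mL/min/kg to 80 mL/min/kg.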

Compound 3, clearance: 80 mL/min/kg
Compound 3: the middle estimate sits 1.9-fold (0.28 log units) below what was measured; the range from low to high includes it.
By their numbers in this assay, from the lowest: compounds 1, 2 and 3 (each within the scatter of the next, the first and the last beyond it).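

In this assay, within the data shown here, methyl in place of acetyl on a nitrogen on an aromatic ring gives a 1.8-fold higher number from compound 2 to compound 3 (0.27 log units; within the scatter), the only step available at this position. Taken alone, it shows that the acetyl, with its hydrogen-bond acceptor, can give way to the smaller methyl on this nitrogen without a difference beyond the scatter, though the step lies close to the edge of it, and a single pair cannot separate a real difference from repeat variation. Nothing measured alongside these compounds offers an explanation for this step.

From the compounds shown here alone, whether a free amine, an ethyl or a longer acyl chain on the same nitrogen would stay within this range remains open. So does whether the same exchange on the core of compound 1 would give a step of similar size.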